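A few compounds are considered here, and "the series" means these few. Any claim that something is new, unique, unknown or untested is made for them only; others in the source may bear on it.

Measured in a functional assay on A549 cells (Homo sapiens) for inhibition, read by CCK-8 assay, with a stated time of 48 h; on this read-out lower numbers stand for stronger inhibition and higher numbers for weaker inhibition:
- compound 1 `COc1cc(-c2ccnc3cc(-c4c[nH]c5ccccc45)nn23)cc(OC)c1OC`: 29 nM
- compound 2 `COc1cc(-c2ccnc3cc(-c4cccc(C)c4)nn23)cc(OC)c1OC`: 5730 nM

Of these two, compound 2 has the higher number, 5730 nM, which makes it the weaker inhibitor. Among the compounds with values here, only one measured step exists so far: a 200-fold higher number from compound 1 to compound 2 (2.30 log units; beyond the scatter). That step put 3-methylphenyl in place of 1H-indol-3-yl.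

The next compound, compound 3 `COc1ccc(-c2cc3nccc(-c4cc(OC)c(OC)c(OC)c4)n3n2)cc1`, keeps the shared core of compound 2 and changes the same position: 4-methoxyphenyl in place of 3-methylphenyl on an aromatic carbon. This swaps one six-membered aromatic carbon ring for another, so the indole-to-phenyl exchange is only a loose guide. Within the data shown here, no measured step shows what this kind of exchange does. A much smaller change than the one seen in this assay for the step to compound 2 therefore seems likely, perhaps with a modestly lower number, and a result within the scatter would be no surprise.

The expected size of the change is a 2.3-fold lower number from compound 2 to compound 3 (0.36 log units; beyond the scatter).

The estimated value for compound 3 is 2500 nM, with an expected range of 500 nM to 10000 nM.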

Compound 3, half-maximal inhibitory concentration: 376 nM
Compound 3: middle estimate off by 6.6-fold (0.82 log units), on the high side, and the stated range ends above it.
By their numbers in this assay, from the lowest: compound 1; then compound 3; then compound 2.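

In this assay, exchanging one six-membered aromatic carbon ring for another at this position has a large effect: 4-methoxyphenyl in place of 3-methylphenyl gives a 15-fold lower number from compound 2 to compound 3 (1.18 log units; beyond the scatter). The first step replaced 1H-indol-3-yl with 3-methylphenyl, so it could not show that the choice of group on the phenyl ring can matter this much on its own. Yet 4-methoxyphenyl does not match 1H-indol-3-yl, as the comparison gives a 13-fold higher number from compound 1 to compound 3 (1.11 log units; beyond the scatter), which leaves compound 1 the strongest inhibitor of the three, and nothing measured here offers a reason for either step.

The step to compound 3 alters two things at once, the group on the phenyl ring and where it sits, so the compounds shown cannot separate the effect of methoxy over methyl from the effect of its location. As far as these compounds go, it therefore remains open whether 4-methylphenyl or 3-methoxyphenyl would fall closer to compound 2 or to compound 3, and how a phenyl ring carrying an amine or a carboxylic acid would compare.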